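The source may hold more compounds than are shown below. What is called first, only, known or untested is meant among the compounds shown, and "the series" means these compounds.

Working notes on the antiproliferative series.

In a functional assay on SW480 cells (Homo sapiens) for antiproliferative activity, read by MTT assay, with a stated time of 72 h (a higher number here means a weaker inhibitor, a lower number a stronger inhibitor), the measured compounds are compound 3 `O=c1cc(CSC(=S)N2CCOCC2)oc2cc(Cl)ccc12`, compound 1 `O=c1cc(CSC(=S)N2CCCC2)oc2cc(Cl)ccc12` and compound 2 `COc1ccc2occ(CSC(=S)N3CCOCC3)c(=O)c2c1`. For compound 3 this assay returns only a limit, > 25000 nM. For compound 1 it likewise returns only a limit, > 25000 nM. The step that the two limits leave unreadable from compound 3 to compound 1, made by pyrrolidin-1-yl in place of morpholin-4-yl on a thiocarbonyl carbon, therefore cannot be read as a number; both ends rest on (the limit of > 25000 nM in this assay, at which 2 of the 3 values shown sit). Among the measured compounds shown here, compound 2 is the one compound with a real number: in this assay compound 2 gives 7100 nM. How the core of compound 2 differs from the core of compound 3 is not broken down here.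

Compound 4 `COc1ccc2occ(CSC(=S)N3CCCC3)c(=O)c2c1` is not yet measured. It arises from compound 2 by pyrrolidin-1-yl in place of morpholin-4-yl on a thiocarbonyl carbon, the same change as from compound 3 to compound 1, at the same place. Since the measured step is unreadable, the step from compound 2 to compound 4 is expected to be small, a 1.0-fold lower number from compound 2 to compound 4 (0.01 log units; within the scatter), resting on compound 2 at 7100 nM. The estimate for compound 4 is 7000 nM, with a range from 2500 nM to 25000 nM.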

Compound 4, half-maximal inhibitory concentration: 4800 nM
The estimate for compound 4 lay 1.5-fold (0.16 log units) above the measured number; low and high end bracket the measured number.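

In this assay, pyrrolidin-1-yl in place of morpholin-4-yl on a thiocarbonyl carbon gives a readable step on the core of compound 2 (a 1.5-fold lower number from compound 2 to compound 4 (0.17 log units; within the scatter)), so on this core the exchange of the two rings leaves the read-out within the usual scatter. The same change on the other core, taking compound 3 to compound 1, cannot be read, since both ends are limits and not numbers: (the limit of > 25000 nM in this assay, at which 2 of the 4 values shown sit). The series therefore shows the size of this change on one core only; it does not show whether the change carries over from one core to another, and a single readable pair supports no general rule.

The compounds shown leave open how other groups on the thiocarbonyl carbon would read, for example piperidin-1-yl or an open-chain diethylamino group. They also leave open whether any group at that place would bring the core of compound 3 to a readable number in this assay.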